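Ethynyl for ethyl: compound 3 to compound 4

This account rests on a few compounds, and the source may have more. Where it says the series, first, only, none or still open, it means among the compounds named here.

Compound 3 `CCc1ccnc(O[C@@H]2CC[C@@H](C)N(C(=O)c3ccccc3-n3nccn3)C2)c1` gives 310 nM in a functional assay on CHO-K1 cells for antagonist activity at Orexin/Hypocretin receptor type 1 (Homo sapiens), read by FLIPR and calcium flux (on this read-out lower numbers stand for stronger inhibition and higher numbers for weaker inhibition), the lowest of the two numbers shown; compound 1 `CC(C)OC(=O)c1ccccc1C(=O)N1C[C@H](Oc2cc(C#N)ccn2)CC[C@H]1C` gives 3300 nM in this assay. Compound 2 `C[C@@H]1CC[C@@H](Oc2cc(C#N)ccn2)CN1C(=O)c1ccccc1CC(F)(F)F` reaches only > 10000 nM in this assay, which is a limit and not a number (the limit of > 10000 nM in this assay, at which 1 of the 3 values shown sits). For the measured compounds named here, the single measured step, an at least 3.0-fold higher number from compound 1 to compound 2 (0.48 log units; beyond the scatter), concerns 2,2,2-trifluoroethyl in place of isopropoxycarbonyl on a different aromatic carbon and does not bear on the present change. Compound 4 `C#Cc1ccnc(O[C@@H]2CC[C@@H](C)N(C(=O)c3ccccc3-n3nccn3)C2)c1` differs from compound 3 by ethynyl in place of ethyl on an aromatic carbon. Going by the values given here, no measured step covers this exchange, so the expected step in this assay, a 1.3-fold higher number from compound 3 to compound 4 (0.11 log units; within the scatter), is none beyond the scatter. Compound 4 is therefore estimated at 400 nM, with a range from 150 nM to 1200 nM.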

Compound 4, half-maximal inhibitory concentration: 240 nM
Beside the measured number, compound 4's estimate is 1.7-fold (0.22 log units) above it; low and high end bracket the measured number.
By their numbers in this assay, from the lowest: compounds 4 and 3 (each within the scatter of the next); then compound 1. At a limit, above all of these: compound 2.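

In this assay, ethynyl in place of ethyl opposite the ring nitrogen gives a 1.3-fold lower number from compound 3 to compound 4 (0.11 log units; within the scatter), so this carbon accepts a triple bond outside aromatic rings with no change beyond the scatter. For the compounds shown here, this is the first measured exchange at this position with the rest of the structure held constant. Nothing measured here accounts for the step.

The compounds shown leave open how an amine, a methoxy group or a longer chain would read on this carbon. Also open, as far as these compounds go, is whether the step holds when isopropoxycarbonyl occupies the other aromatic ring.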